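Trading a diol amide side chain for a pyrrolidine

The source may report more compounds than this note shows. Statements on the series, on what has been measured and on what is new or still open speak of the compounds shown alone.

Among the measured compounds shown here, compound 2 `Cn1ncc(Cl)c1-c1cc(C(=O)N[C@@H]2CN[C@H](CC(=O)NCC(O)CO)C[C@H]2c2ccc(Cl)c(Cl)c2)oc1Cl` is one of two compounds measured here. In an assay for inhibition of RAC-alpha serine/threonine-protein kinase (Homo sapiens), read by HTRF, with a stated time of 1 h (a lower number here means a stronger inhibitor, a higher number a weaker inhibitor), compound 2 gives 3.13 nM, which is the higher of the two numbers. For the measured compounds named here, its only neighbour, compound 1 `Cn1ncc(Cl)c1-c1cc(C(=O)N[C@@H]2CN[C@H](CCCO)C[C@H]2c2ccc(Cl)c(Cl)c2)oc1Cl`, gives 2.56 nM in this assay, and the two numbers lie within the scatter of each other, so no order between them can be claimed. Going by the values given here, the one measured step, a 1.2-fold higher number from compound 1 to compound 2 (0.09 log units; within the scatter), exchanged one side chain for another at a saturated chain carbon bound to a saturated ring carbon without moving the number beyond the scatter.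

Compound 3 `Cn1ncc(Cl)c1-c1cc(C(=O)N[C@@H]2CN[C@H](CCN3CCCC3)C[C@H]2c2ccc(Cl)c(Cl)c2)oc1Cl` is not yet measured. It differs from compound 2 as follows: (pyrrolidin-1-yl)methyl in place of (2,3-dihydroxypropyl)carbamoyl on a saturated chain carbon bound to a saturated ring carbon. This change sits at the same place that the step from compound 1 to compound 2 already altered, and that step stayed within the scatter. On that single precedent the step is expected to be small, a 1.0-fold lower number from compound 2 to compound 3 (0.02 log units; within the scatter), with no direction favoured beyond the scatter. Compound 3 is therefore estimated at 3 nM, expected to fall between 1 nM and 10 nM.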

Compound 3, half-maximal inhibitory concentration: 6.41 nM
Compound 3: middle estimate off by 2.1-fold (0.33 log units), on the low side; the measured number falls inside the stated range.
By their numbers in this assay, from the lowest: compounds 1 and 2 (each within the scatter of the next); then compound 3.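

In this assay this place on the chain turns out not to be indifferent to what it carries: (pyrrolidin-1-yl)methyl in place of (2,3-dihydroxypropyl)carbamoyl gives a 2.0-fold higher number from compound 2 to compound 3 (0.31 log units; beyond the scatter) and pyrrolidin-1-yl in place of hydroxymethyl gives a 2.5-fold higher number from compound 1 to compound 3 (0.40 log units; beyond the scatter) so both steps are modest, yet both lie beyond the scatter, which the earlier step did not. Compound 3 is therefore the weakest of the three, although it remains a low-nanomolar inhibitor. The hydroxyl-ended chain of compound 1 and the much larger diol amide chain of compound 2 stay within the scatter of each other, while only the chain ending in the pyrrolidine ring stands apart, and nothing available explains that difference.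

With three compounds, the change cannot be pinned on one feature, as the pyrrolidine differs from the other two side chains both in its ring and in its nitrogen and in lacking the hydroxyl groups. An open-chain dimethylamino group, a morpholine ring or a terminal carboxylic acid at the same place would help to separate these features.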